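Swapping trifluoromethyl for fluoro on the benzylidene arm

The source may report more compounds than this note shows. Statements on the series, on what has been measured and on what is new or still open speak of the compounds shown alone.

Measured so far:
- Compound 1 `C=CCn1c(=O)/c(=C\c2cccc(F)c2)[nH]c(=O)/c1=C\c1ccccc1OC` gives 6500 nM
- Compound 2 `C=CCn1c(=O)/c(=C\c2ccccc2C(F)(F)F)[nH]c(=O)/c1=C\c1ccccc1OC` gives 4400 nM

Both compounds share the same core and were tested in a functional assay on MOLT-4 cells (Homo sapiens) for cytotoxicity, read by CCK-8 assay, with a stated time of 72 h; on this read-out higher numbers stand for weaker inhibition and lower numbers for stronger inhibition. Compound 2 holds the lowest of the two numbers, but its step from compound 1 a 1.5-fold lower number from compound 1 to compound 2 (0.17 log units; within the scatter) is within the scatter, so the two values cannot be told apart with confidence.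

Compound 3 `C=CCn1c(=O)/c(=C\c2ccccc2F)[nH]c(=O)/c1=C\c1ccccc1OC` has not yet been tested. It differs from compound 2 by fluoro in place of trifluoromethyl on an aromatic carbon of a six-membered aromatic ring of carbon only, ortho to a large group.

Among the compounds with values here, only one measured step touches this arm of the molecule, and it changes both the substituent and its position at once: the step from compound 1 to compound 2 a 1.5-fold lower number from compound 1 to compound 2 (0.17 log units; within the scatter) stayed within the scatter. Nothing measured here separates the effect of the substituent's size from its position. The expectation for compound 3 is therefore a step of a 1.1-fold higher number from compound 2 to compound 3 (0.06 log units; within the scatter) of no meaningful size in this assay. The estimated value for compound 3 is 5000 nM, with a range from 2000 nM to 12000 nM.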

Compound 3, half-maximal inhibitory concentration: 20000 nM
For compound 3 the middle estimate is 4.0-fold (0.60 log units) below the measured one, outside the stated range (above it).
By their numbers in this assay, from the lowest: compounds 2 and 1 (each within the scatter of the next); then compound 3.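

On the ortho carbon of this arm, the substituent matters. In this assay, fluoro in place of trifluoromethyl gives a 4.5-fold higher number from compound 2 to compound 3 (0.66 log units; beyond the scatter), a step beyond the scatter and the first sign in this small set that changing this group can move the read-out. The third compound also pulls apart two things that were tied together before, the substituent and its place: with fluoro kept, 2-fluorophenyl in place of 3-fluorophenyl gives a 3.1-fold higher number from compound 1 to compound 3 (0.49 log units; beyond the scatter), so the place of a single fluoro also counts, and 2-fluorophenyl stands apart from the two other arms, whose values lie within the scatter of each other. Nothing available here explains why the 2-fluorophenyl arm gives the higher number.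

The compounds shown leave open whether trifluoromethyl would hold its value in the place fluoro takes in 3-fluorophenyl, since that arm appears only with fluoro. They also leave open how this ortho carbon would respond to a quite different group, such as a nitrile or an amine, and whether the same pattern would hold with another group on the second arm.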